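The source may report more compounds than this note shows. Statements on the series, on what has been measured and on what is new or still open speak of the compounds shown alone.

Going by the values given here, in a functional assay on OVCAR-3 cells (Homo sapiens) for inhibition, read by MTT assay, with a stated time of 24 h (on this read-out lower numbers stand for stronger inhibition and higher numbers for weaker inhibition), compound 3 (`Cc1ccc(-n2cc(CN3C(=O)C[C@@H]4CC[C@@]3(C)C4(C)C)nn2)cc1`) gives 40 nM and holds the lowest of the three numbers so far, ahead of compound 1 (`CC1(C)[C@H]2CC[C@]1(C)N(Cc1cn(-c3ccccc3Br)nn1)C(=O)C2`) at 140 nM and compound 2 (`COc1ccccc1-n1cc(CN2C(=O)C[C@@H]3CC[C@@]2(C)C3(C)C)nn1`) at 140 nM on the same test. The next compound, compound 4 (`Cc1ccccc1-n1cc(CN2C(=O)C[C@@H]3CC[C@@]2(C)C3(C)C)nn1`), has the same atoms as compound 3 joined differently (2-methylphenyl in place of 4-methylphenyl on an aromatic nitrogen), with 2-methylphenyl in place of 4-methylphenyl on an aromatic nitrogen. Its methyl therefore sits at the ring place where compound 1 has its bromo and compound 2 its methoxy. The closest evidence comes from two modest steps beyond the scatter (a 3.5-fold lower number from compound 1 to compound 3 (0.54 log units; beyond the scatter)) and (a 3.5-fold lower number from compound 2 to compound 3 (0.54 log units; beyond the scatter)), while swapping bromo for methoxy moved nothing (no change at the digits printed from compound 1 to compound 2 (within the scatter)). Among the compounds with values here, no measured pair isolates the methyl move itself, so the expectation is loose: a higher number in this assay that gives back most of that gap. The estimated change is (a 3.0-fold higher number from compound 3 to compound 4 (0.48 log units; beyond the scatter)). Compound 4 is therefore expected near 120 nM (estimated range 50 nM to 280 nM).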

Compound 4, half-maximal inhibitory concentration: 150 nM
The estimate for compound 4 lay 1.3-fold (0.10 log units) below the measured number; measured number inside the range.
By their numbers in this assay, from the lowest: compound 3; then compounds 1, 2 and 4 (each within the scatter of the next).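

In this assay, moving the methyl alone, with the atoms unchanged, gives a 3.8-fold higher number from compound 3 to compound 4 (0.57 log units; beyond the scatter), so where this one group sits on the phenyl ring matters in its own right. The ring place held by the methyl of 2-methylphenyl also looks indifferent to the group tried there: methyl in place of methoxy gives a 1.1-fold higher number from compound 2 to compound 4 (0.03 log units; within the scatter), and methyl in place of bromo gives a 1.1-fold higher number from compound 1 to compound 4 (0.03 log units; within the scatter), both within the scatter. No measurement at hand accounts for this difference between the two methyl places.

Compound 3 alone carries a group at its ring place, so the lower number there rests on methyl only. From the compounds shown here alone, whether bromo, methoxy, an amine or a carboxylic acid at that place would keep the lower number remains open.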